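From carboxy to methoxycarbonyl: compound 3 to compound 4

The source may hold more compounds than are shown below. What is called first, only, known or untested is meant among the compounds shown, and "the series" means these compounds.

Measured in a physicochemical assay for acid dissociation, so far
Compound 1 `NS(=O)(=O)c1ccc(S(=O)(=O)CCCO)cc1` gives 8.98
Compound 2 `COC(=O)c1cc(S(N)(=O)=O)ccc1S(=O)(=O)CCO` gives 9.2
Compound 3 `NS(=O)(=O)c1ccc(S(=O)(=O)CCCO)c(C(=O)O)c1` gives 9.28

Compound 3 stands level with compound 1 and compound 2 within the scatter. Compound 4 `COC(=O)c1cc(S(N)(=O)=O)ccc1S(=O)(=O)CCCO` differs from compound 3 by methyl in place of hydrogen on an oxygen next to a carbonyl group in the form carboxy to methoxycarbonyl. Within the data shown here, the one measured step bearing on the carboxy group is a number 0.30 log units higher from compound 1 to compound 3 (within the scatter) and it stays within the scatter. Compound 2 also carries methoxycarbonyl and sits at (9.2) within the same band. No step beyond the scatter is therefore expected in this assay. The expected step is a number 0.18 log units lower from compound 3 to compound 4 (within the scatter) and it is small. For compound 4 the estimate is 9.1 with an expected range (8.8 to 9.4).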

Compound 4, acid dissociation constant: 8.9
Compound 4: middle estimate off by 0.20 log units, on the high side, within the range that was stated.
By their numbers in this assay, from the lowest: compounds 4, 1, 2 and 3 (each within the scatter of the next, the first and the last beyond it).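

In this assay, among these compounds, methyl in place of hydrogen on the oxygen next to the carbonyl group gives the only step so far beyond the scatter (a number 0.38 log units lower from compound 3 to compound 4 (beyond the scatter)). The step that brings in methoxycarbonyl on an aromatic carbon stays within it (a number 0.08 log units lower from compound 1 to compound 4 (within the scatter)), as does hydroxymethyl in place of hydroxy on the chain (a number 0.30 log units lower from compound 2 to compound 4 (within the scatter)). No evidence is available to account for these steps.

Going by these compounds, it remains open whether an ethyl ester or a primary amide in place of methoxycarbonyl would stand nearer compound 3 or compound 4 in this assay.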